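Coumarin series: substituent variation at the amine-bearing aromatic carbon

The source may report more compounds than this note shows. Statements on the series, on what has been measured and on what is new or still open speak of the compounds shown alone.

Measured compounds in an assay on isolated protein (strain Sprague-Dawley) for inhibition of Amine oxidase [flavin-containing] B (Rattus norvegicus), read by spectrophotometry, with a stated time of 5 min; a higher number here means a weaker inhibitor, a lower number a stronger inhibitor:
compound 1 `COCOc1cc(=O)oc2cc(OCc3cccc(Cl)c3)ccc12`, 100 nM
compound 2 `CNc1cc(=O)oc2cc(OCc3cccc(Cl)c3)ccc12`, 8.71 nM
compound 3 `CCNc1cc(=O)oc2cc(OCc3cccc(Cl)c3)ccc12`, 28.2 nM

Compound 3 stands second highest of the three numbers, its nearest neighbour compound 2 and its furthest compound 1. The steps of an 11-fold lower number from compound 1 to compound 2 (1.06 log units; beyond the scatter) and a 3.5-fold lower number from compound 1 to compound 3 (0.55 log units; beyond the scatter) both lower the number when an alkylamino group replaces methoxymethoxy at this carbon, while a 3.2-fold higher number from compound 2 to compound 3 (0.51 log units; beyond the scatter) raises it. Compound 4 `O=c1cc(CO)c2ccc(OCc3cccc(Cl)c3)cc2o1` carries hydroxymethyl in place of ethylamino on an aromatic carbon. For the measured compounds named here, no measured step makes this exact exchange; the only related step, a 3.5-fold lower number from compound 1 to compound 3 (0.55 log units; beyond the scatter), suggests that an oxygen-bearing group here gives a higher number than ethylamino. Compound 4 is therefore expected to give a modestly higher number, an estimated 2.1-fold higher number from compound 3 to compound 4 (0.33 log units; beyond the scatter). The estimate for compound 4 is 60 nM, between 15 nM and 250 nM.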

Compound 4, half-maximal inhibitory concentration: 5.25 nM
Compound 4: middle estimate off by 11-fold (1.06 log units), on the high side; measured number outside the range, below it.
By their numbers in this assay, from the lowest: compounds 4 and 2 (each within the scatter of the next); then compound 3; then compound 1.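

Hydroxymethyl on this aromatic carbon matches or betters the alkylamino groups: a 5.4-fold lower number from compound 3 to compound 4 (0.73 log units; beyond the scatter) is beyond the scatter, while a 1.7-fold lower number from compound 2 to compound 4 (0.22 log units; within the scatter) lies within it and leaves compound 2 and compound 4 unordered. An oxygen-bearing group here does not by itself give a high number, since a 19-fold lower number from compound 1 to compound 4 (1.28 log units; beyond the scatter) separates hydroxymethyl from methoxymethoxy by a large margin. No evidence is available to explain these differences. Open, going by these compounds, is how a longer chain such as 2-hydroxyethyl, a methoxymethyl group or a carboxylic acid on this carbon would compare.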